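Dimethylaminomethyl in place of chloro on compound 3

This account rests on a few compounds, and the source may have more. Where it says the series, first, only, none or still open, it means among the compounds named here.

Three compounds share the core. Compound 1 `Cc1noc(NS(=O)(=O)c2cccc3c(NC(=O)C(C)C)cccc23)c1C` gives 880 nM in an assay on VSM-A10 cells for antagonist activity at Endothelin-1 receptor (Rattus norvegicus); on this read-out lower numbers stand for stronger inhibition and higher numbers for weaker inhibition. Compound 2 `Cc1noc(NS(=O)(=O)c2cccc3c(N4CCCCC4=O)cccc23)c1C` gives 270 nM. Compound 3 `Cc1noc(NS(=O)(=O)c2cccc3c(Cl)cccc23)c1C` gives 24000 nM and stands highest of the three numbers, with a 27-fold higher number from compound 1 to compound 3 (1.44 log units; beyond the scatter) and an 89-fold higher number from compound 2 to compound 3 (1.95 log units; beyond the scatter) both beyond the scatter. Compound 4 `Cc1noc(NS(=O)(=O)c2cccc3c(CN(C)C)cccc23)c1C` is not yet measured; the change is (dimethylamino)methyl in place of chloro on an aromatic carbon. Both measured steps into compound 3 replace a substituent carrying a carbonyl with chloro and give large rises; the step into compound 4 reverses the direction, adding a group of four heavy atoms with one hydrogen-bond acceptor but no carbonyl. Within the data shown here, no measured step tests this group itself, so the expected step is smaller than the reverse of either measured one. The number for compound 4 is expected at 5000 nM, within 1500 nM to 16000 nM, that is an estimated 4.8-fold lower number from compound 3 to compound 4 (0.68 log units; beyond the scatter).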

Compound 4, half-maximal inhibitory concentration: 2800 nM
Estimate against measurement, compound 4: 1.8-fold (0.25 log units) above; measured number inside the range.
By their numbers in this assay, from the lowest: compound 2; then compound 1; then compound 4; then compound 3.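

In this assay, the step of an 8.6-fold lower number from compound 3 to compound 4 (0.93 log units; beyond the scatter) shows that a substituent without a carbonyl can also lower the number relative to chloro on this aromatic carbon, so among these four compounds a carbonyl is not needed for a step down from chloro. The (dimethylamino)methyl group still does not match either carbonyl-bearing group, with a 3.2-fold higher number from compound 1 to compound 4 (0.50 log units; beyond the scatter) and a 10-fold higher number from compound 2 to compound 4 (1.02 log units; beyond the scatter) as the steps, and the gap to the 2-oxopiperidin-1-yl group is the larger of the two. No measurement at hand gives a reason for these steps.

The compounds shown leave open whether the nitrogen of the (dimethylamino)methyl group or the carbon atoms around it carry the step down from chloro, and a tert-butyl group on the same aromatic carbon would separate the two. As far as these compounds go, how a longer chain ending in the same amine, or a carboxylic acid at this place, would read also remains open.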